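Changing the aromatic nitrogen substituent: towards compound 3

The source may hold more compounds than are shown below. What is called first, only, known or untested is meant among the compounds shown, and "the series" means these compounds.

In a functional assay on KG-1 cells (Homo sapiens) for antiproliferative activity, read by CCK-8 assay, with a stated time of 72 h (a lower number here means a stronger inhibitor, a higher number a weaker inhibitor), compound 1 `CCn1cc(-c2n[nH]c3cc(-c4cc(C(=O)Nc5cccc(C(F)(F)F)c5)ccc4C)ccc23)cn1` gives 257 nM, and compound 2 `Cc1ccc(C(=O)Nc2cccc(C(F)(F)F)c2)cc1-c1ccc2c(-c3cnn(CC(=O)N(C)C)c3)n[nH]c2c1` gives 441 nM, so the two values lie within the scatter of each other. Compound 3 `Cc1ccc(C(=O)Nc2cccc(C(F)(F)F)c2)cc1-c1ccc2c(-c3cnn(C4CCN(C)CC4)c3)n[nH]c2c1` carries 1-methylpiperidin-4-yl in place of (dimethylcarbamoyl)methyl on an aromatic nitrogen. Within the data shown here, the only measured step at this substituent is a 1.7-fold higher number from compound 1 to compound 2 (0.23 log units; within the scatter). Among the measured compounds shown here, it bears only loosely, since no measured compound has a ring there, and no shift beyond the scatter is expected. The estimated step is a 1.5-fold lower number from compound 2 to compound 3 (0.17 log units; within the scatter). The expected value for compound 3 is 300 nM, with an estimated range of 100 nM to 900 nM.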

Compound 3, half-maximal inhibitory concentration: 93.3 nM
Beside the measured number, compound 3's estimate is 3.2-fold (0.51 log units) above it; the whole stated range lies above it.
By their numbers in this assay, from the lowest: compound 3; then compounds 1 and 2 (each within the scatter of the next).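

In this assay the substituent on this aromatic nitrogen can move the number beyond the scatter, which the step between the two open-chain groups did not show: there is a 4.7-fold lower number from compound 2 to compound 3 (0.67 log units; beyond the scatter) and also a 2.8-fold lower number from compound 1 to compound 3 (0.44 log units; beyond the scatter) at the same position. Both steps bring in 1-methylpiperidin-4-yl, the only substituent here with a ring, and the shift appears against ethyl as well as against (dimethylcarbamoyl)methyl. No evidence given here accounts for the shift.

Open, on these data alone, is whether the shift follows the ring or its nitrogen, which a cyclohexyl or tetrahydropyran-4-yl group at this position would separate. Also open, as far as these compounds go, is whether a longer chain ending in a dimethylamino group would match compound 3.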